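The compounds below may be only part of what the source reports. "The series", "measured", "known", "first", "only" and "open" are said of these compounds alone.

Among the measured compounds shown here, compound 1 `COc1ccccc1CNc1nc2c(N)ncnc2n1[C@@H]1O[C@H](CO)[C@@H](O)[C@H]1O` is one of two compounds so far measured in an assay on COS-7 cells for inhibition of sodium/nucleoside cotransporter 2 (Homo sapiens), read by scintillation counting, in the presence of a further agent that is not named here; on this read-out lower numbers stand for stronger inhibition and higher numbers for weaker inhibition. In this assay compound 1 returns only a limit, > 100000 nM. Compound 2 `CCNC(=O)OC[C@H]1O[C@@H](n2cnc3c(N)ncnc32)[C@H](O)[C@@H]1O` likewise returns only a limit in this assay, > 100000 nM. Both readings sit at the limit of > 100000 nM in this assay, at which 2 of the 2 values shown sit, so compound 1 stands nowhere more definite than that ceiling. Compound 3 `Cc1cccc(CNc2nc3c(N)ncnc3n2[C@@H]2O[C@H](CO)[C@@H](O)[C@H]2O)c1` is not yet measured; it differs from compound 1 by 3-methylphenyl in place of 2-methoxyphenyl on a saturated chain carbon bound to a nitrogen on an aromatic ring. For the measured compounds named here, no measured step exists to guide the size of this change, so no shift beyond the scatter is expected. Compound 3 is expected to give about 150000 nM in this assay, within 30000 nM to 600000 nM. The expected step is a step that the limit leaves unreadable from compound 1 to compound 3, essentially none.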

Compound 3, half-maximal inhibitory concentration: 19000 nM
Estimate against measurement, compound 3: 7.9-fold (0.90 log units) above; the whole stated range lies above it.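

In this assay, 3-methylphenyl in place of 2-methoxyphenyl on a saturated chain carbon bound to a nitrogen on an aromatic ring gives an at least 5.2-fold lower number from compound 1 to compound 3 (0.72 log units; beyond the scatter). This position therefore responds to a change of aryl group, and compound 3 is the only compound shown that returns a number rather than a limit. The step is only a lower bound on the true size, as the value for compound 1 is a limit: the limit of > 100000 nM in this assay, at which 2 of the 3 values shown sit.

The compounds shown leave open whether the step follows from the methyl group or from its place on the ring, as 3-methoxyphenyl and 2-methylphenyl are not among them. Also open, as far as these compounds go, is how a carboxylic acid or an amine on that ring, or a longer chain to it, would read.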